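Acetyl in Place of Chloro on a Weak Antiproliferative Anilide

The compounds below may be only part of what the source reports. "The series", "measured", "known", "first", "only" and "open" are said of these compounds alone.

Compound 2 `COc1ccc(C(=O)Nc2cccc(Cl)c2)cc1Nc1nccc(-c2cccnc2)n1` was tested in a functional assay on K562 cells (Homo sapiens) for antiproliferative activity, read by MTT assay, with a stated time of 48 h (a lower number here means a stronger inhibitor, a higher number a weaker inhibitor), where compound 2 gives 237000 nM. This is the only number shown for the series: the related compound 1 `COc1ccc(C(=O)Nc2nccs2)cc1Nc1nccc(-c2cccnc2)n1` carries the entry "not determined" (no result reported) in this assay, so compound 2 stands alone and cannot be ranked against a measured neighbour. Compound 3 `COc1ccc(C(=O)Nc2cccc(C(C)=O)c2)cc1Nc1nccc(-c2cccnc2)n1` differs from compound 2 in a single place: acetyl in place of chloro on an aromatic carbon. Within the data shown here, no step between measured compounds is available to guide the expectation for this assay. As compound 2 gives 237000 nM, and nothing in the data shows that this exchange moves the readout, compound 3 is expected to remain in the same region. The step is expected to be a 1.2-fold lower number from compound 2 to compound 3 (0.07 log units; within the scatter), which is no more than the scatter of repeated measurements. Compound 3 is therefore estimated at 200000 nM in this assay, between 60000 nM and 600000 nM.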

Compound 3, half-maximal inhibitory concentration: 237000 nM
For compound 3 the middle estimate is 1.2-fold (0.07 log units) below the measured one; measured number inside the range.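

In this assay, among these compounds, acetyl in place of chloro on an aromatic carbon gives no change at the digits printed from compound 2 to compound 3 (within the scatter), the first step that can be read at all. It shows that this place, on a six-membered aromatic ring of carbon only and meta to a large group, can carry the acetyl, with its three heavy atoms and one hydrogen-bond acceptor, in place of the single chlorine, and that compound 2 and compound 3 still read alike and remain weak. No accompanying evidence bears on why the two compounds read alike.

From the compounds shown here alone, whether an amine, a carboxylic acid or a longer alkyl chain on the same aromatic carbon would read any differently stays open. A single step also cannot show whether any group at this place can bring the number away from that of compound 2.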